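The compounds below may be only part of what the source reports. "The series", "measured", "known", "first", "only" and "open" are said of these compounds alone.

Measured compounds in this series:

compound 1 `COc1cc(-c2cnn3cc(OC)c(C(C)C)nc23)ccn1`: 14%
compound 2 `COc1cc(-c2cnn3cc(OC)c(C(C)(C)O)nc23)ccn1`: 92%
compound 3 `CNc1nc2c(-c3ccnc(OC)c3)cnn2cc1OC`: 74%

In an ADME assay on microsomes from liver (Rattus norvegicus) for metabolic stability, with a stated time of 60 min, tested at 1 uM (a higher number here means that more of the compound is left, a lower number that less of the compound is left), compound 3 stands second highest of the three numbers: it is separated from the highest by a number 18 percentage points lower from compound 2 to compound 3 (beyond the scatter) and from the lowest by a number 60 percentage points higher from compound 1 to compound 3 (beyond the scatter). Both of these steps exchange the whole group on the aromatic carbon of the shared core, and both lie beyond the scatter.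

Compound 4 `COc1cc(-c2cnn3cc(OC)c(N(C)C)nc23)ccn1` differs from compound 3 by methyl in place of hydrogen on a nitrogen on an aromatic ring. Within the data shown here, no measured step touches the nitrogen of the methylamino group; the two large steps recorded, a number 60 percentage points higher from compound 1 to compound 3 (beyond the scatter) and a number 18 percentage points lower from compound 2 to compound 3 (beyond the scatter), replace the substituent on the aromatic carbon as a whole and so bear only indirectly on a change confined to one methyl on that nitrogen. The change is small in what is counted, so a step of the size seen between compound 1 and compound 3 is not expected; a modest move, more likely downward from compound 3 than upward, or no step beyond the scatter, is the expectation.

Compound 4 is therefore expected to give 60%, within 35% to 85%, which means an expected step of a number 14 percentage points lower from compound 3 to compound 4 (beyond the scatter).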

Compound 4, percent of the compound remaining: 3%
Beside the measured number, compound 4's estimate is 57 percentage points above it, and the stated range ends above it.
By their numbers in this assay, from the lowest: compound 4; then compound 1; then compound 3; then compound 2.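

Changing methylamino to dimethylamino gives a number 71 percentage points lower from compound 3 to compound 4 (beyond the scatter) in this assay and so shows that one methyl on this nitrogen can outweigh the exchanges of the whole group seen so far. A nitrogen on this aromatic carbon therefore does not by itself go with a high number: dimethylamino stands at the bottom of the set, with a number 89 percentage points lower from compound 2 to compound 4 (beyond the scatter) against the 1-hydroxy-1-methylethyl compound and a number 11 percentage points lower from compound 1 to compound 4 (beyond the scatter) against the isopropyl compound, while methylamino stays near the top. No measurement here bears on why the second methyl has this effect.

As far as these compounds go, it remains open whether the hydrogen on the nitrogen is what matters or whether the size of the group does, which an unsubstituted amino group, ethylamino, or a ring amine such as azetidine or morpholine in this place would begin to separate. Also open, from the compounds shown here alone, is whether methoxyethylamino or another longer chain on the nitrogen stays with methylamino or falls with dimethylamino in this assay when the rest of the shared core is kept.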